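A few compounds are considered here, and "the series" means these few. Any claim that something is new, unique, unknown or untested is made for them only; others in the source may bear on it.

Measured compounds in the series:

- compound 1 `COc1cccc(C(=O)NCCNc2cccc(NS(=O)(=O)c3cc(-c4cccc(C(=O)N(C)C)c4)ccc3OC)c2)c1` — 9250 nM in a functional assay on CHO-K1 cells for agonist activity at Orexin/Hypocretin receptor type 1 (Homo sapiens), read by calcium flux; on this read-out lower numbers stand for an effect already at smaller amounts and higher numbers for an effect only at larger amounts of compound
- compound 2 `COc1ccc(C(=O)NCCNc2cccc(NS(=O)(=O)c3cc(-c4cccc(C(=O)N(C)C)c4)ccc3OC)c2)cc1` — "not determined" (no result reported) in this assay
- compound 3 `COc1ccc(-c2cccc(C(=O)N(C)C)c2)cc1S(=O)(=O)Nc1cccc(NCCNC(=O)c2ccccc2C)c1` — "not determined" (no result reported) in this assay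

Compound 2 stands without a number of its own: in this assay its entry reads "not determined" (no result reported), and compound 3 is in the same position with "not determined" (no result reported). Going by the values given here, the only number in the set belongs to compound 1, which in this assay gives 9250 nM. Among the compounds with values here, nothing therefore fixes where compound 2 lies, and no pair of measured compounds differs in one place, so no step of known size is available for comparison.

Compound 4 `COc1ccc(-c2cccc(C(=O)N(C)C)c2)cc1S(=O)(=O)Nc1cccc(NCCNC(=O)c2cccc(Cl)c2)c1` is the next compound to be run in this assay. It differs from compound 2 in one place: 3-chlorophenyl in place of 4-methoxyphenyl on a carbonyl carbon. The carbonyl carbon that carries the ring keeps its amide-type nitrogen neighbour; the rest of the molecule is unchanged.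

Within the data shown here, with no measured step between any pair of compounds, the size and direction of the change from compound 2 to compound 4 cannot be read from the data; the expectation is that it stays within the usual scatter rather than moving clearly either way. Among the measured compounds shown here, the only anchor is compound 1, whose reading in this assay is 9250 nM. On that anchor compound 4 is estimated at 8000 nM in this assay, expected between 2000 nM and 30000 nM.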

Compound 4, half-maximal effective concentration: 5720 nM
For compound 4 the middle estimate is 1.4-fold (0.15 log units) above the measured one; the measured number falls inside the stated range.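

In this assay the series now has its first readable step, a 1.6-fold lower number from compound 1 to compound 4 (0.21 log units; within the scatter), for chloro in place of methoxy on an aromatic carbon of the ring carried by the carbonyl carbon. At this place, the two substituents cannot be told apart on this read-out, so the exchange gives no sign that the identity of this one group governs the result. Steps involving compound 2 or compound 3 cannot be read, as neither has a number, and the comparison of the 4-methoxyphenyl and 3-chlorophenyl amides therefore stays without a size or direction. No measurement at hand bears on why the exchange gives this result.

Still open, from the compounds shown here alone, is whether an amine or a carboxylic acid on this ring would give a step beyond the scatter, which would show whether the position responds to any exchange at all. Also open, going by these compounds, is how a longer chain between the amide-type nitrogen and the shared core, or a replacement of the dimethylamide group, would read in this assay.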